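Methoxy in place of phenyl on a carbonyl carbon

The source may hold more compounds than are shown below. What is called first, only, known or untested is meant among the compounds shown, and "the series" means these compounds.

Of the compounds shown here, three sharing one core have been measured in a physicochemical assay for lipophilicity, at pH 7.4; a higher number here means a more lipophilic compound, a lower number a more polar compound. Among the compounds with values here, compound 1 `Cc1cc(C(=O)Nc2c(F)cccc2F)nn1Cc1cc(Cl)ccc1OCc1ccccc1` gives 3.7, the only true number so far. Compound 2 `Cc1cc(C(=O)NCc2cccnc2)nn1Cc1cc(Cl)ccc1OCc1ccccc1` gives > 3.7, which is a limit of the assay and not a number. Compound 3 `Cc1cc(NC(=O)c2ccccc2)nn1Cc1cc(Cl)ccc1OCc1ccccc1` gives > 3.7, which is also a limit and not a number. Compound 3 therefore stands at the limit of > 3.7 in this assay, at which 2 of the 3 values shown sit.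

Compound 4 `COC(=O)Nc1cc(C)n(Cc2cc(Cl)ccc2OCc2ccccc2)n1` differs from compound 3 in one place: methoxy in place of phenyl on a carbonyl carbon. Methoxy stands in place of phenyl on a carbonyl carbon, so benzamido becomes (methoxycarbonyl)amino.

Within the data shown here, three measured steps bear on this change, and none has a readable size. They are a number no lower from compound 1 to compound 2 (the limit leaves the size open), a number no lower from compound 1 to compound 3 (the limit leaves the size open) and a step that the two limits leave unreadable from compound 2 to compound 3. None of them swaps phenyl for methoxy, so they give only a loose guide to this assay. Among the measured compounds shown here, the best anchor is compound 1 at 3.7, the one measured number. The expected change is a number at least 0.10 log units lower from compound 3 to compound 4 (that floor lies within the scatter), an estimated move toward a lower number whose size remains uncertain. For compound 4 the estimated value is 3.6, with an expected range from 3.1 to 4.2.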

Compound 4, distribution coefficient: > 3.7
Compound 4 was reported as a limit (the forecaster's own chance of this, stated with the estimate: 40%); middle value at least 0.10 log units away from the limit.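

In this assay, compound 4 gives a limit of the assay and not a number (> 3.7). Within the data shown here, only one new step gives a direction (a number no lower from compound 1 to compound 4 (the limit leaves the size open)). Among these compounds, removing the phenyl ring from this carbonyl carbon and putting methoxy there, with its one hydrogen-bond acceptor, therefore still gives no true number, something the earlier compounds could not show, since each of them carries a ring on this side of the core. None of the new steps can be read for size, and the result places one more compound at the same limit: (the limit of > 3.7 in this assay, at which 3 of the 4 values shown sit).

From the compounds shown here alone, how far compound 2, compound 3 and compound 4 lie past that limit stays open, so the size of the swap from phenyl to methoxy remains unknown. Also open, going by these compounds, is what a carboxylic acid or an amine in place of methoxy on this carbonyl carbon would give, and whether either would yield a true number.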